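Swapping a Methoxyphenyl for a Fluorophenyl on an Amide

The source may hold more compounds than are shown below. What is called first, only, known or untested is meant among the compounds shown, and "the series" means these compounds.

Two compounds share one core and differ only in the ring carried on an amide-type nitrogen. Compound 1 `COc1cccc(NC(=O)CCc2nc(Cc3ccc(NC(C)=O)cc3)no2)c1` gives 35.6% in a functional assay on the whole organism (strain C57BL/6) for inhibition, with Mus musculus as the target, read by paw edema, with stated times of 1 h and 4 h, at a dose of 100 mg/kg by the oral route; on this read-out lower numbers stand for less inhibition and higher numbers for more inhibition at the one dose given (going by the name of the read-out). Within the data shown here, compound 2 `COc1ccc(NC(=O)CCc2nc(Cc3ccc(NC(C)=O)cc3)no2)cc1` gives 49.3% in this assay, the higher of the two numbers, and the only measured step is a number 13.7 percentage points higher from compound 1 to compound 2 (beyond the scatter). Compound 3 `CC(=O)Nc1ccc(Cc2noc(CCC(=O)Nc3ccccc3F)n2)cc1` is not yet measured; it differs from compound 2 by 2-fluorophenyl in place of 4-methoxyphenyl on an amide-type nitrogen. Among the measured compounds shown here, the single measured step concerns where a methoxy group sits on the ring, not the exchange of that ring for a fluorine-bearing one, so it bears only loosely on the present change. For the measured compounds named here, no measured compound carries a 2-fluorophenyl, so the direction cannot be read from the data, and a step either way, within or somewhat beyond the scatter, remains plausible. Compound 3 is therefore expected to give about 40%, somewhere between 20% and 60%, which amounts to an estimated step of a number 9.3 percentage points lower from compound 2 to compound 3 (within the scatter).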

Compound 3, a percentage reported as inhibition, in the whole organism at one dose (the size of the read-out at that dose, not a potency): 67.1%
Compound 3: middle estimate off by 27.1 percentage points, on the low side, outside the stated range (above it).
By their numbers in this assay, from the lowest: compound 1; then compound 2; then compound 3.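

There is a number 17.8 percentage points higher from compound 2 to compound 3 (beyond the scatter) and a number 31.5 percentage points higher from compound 1 to compound 3 (beyond the scatter) in this assay when 2-fluorophenyl takes the place of a methoxy-bearing ring on the amide-type nitrogen. Among these compounds, the earlier pair showed only that moving the methoxy group shifts the number, whereas these steps show that, among the three compounds, a methoxy group on this ring is not needed for a high reading at the one dose given and that exchanging the group can shift the number further than moving the methoxy did. Nothing available explains the rise.

On these data alone, it remains open whether the gain comes from adding the fluorine or from losing the methoxy group, a question that a plain phenyl on the same nitrogen could help to settle. As far as these compounds go, how a chlorophenyl or a saturated cyclohexyl ring would read at this place also remains unknown.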